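The source may report more compounds than this note shows. Statements on the series, on what has been measured and on what is new or still open speak of the compounds shown alone.

Of the compounds shown here, two have been measured in a functional assay on L02 cells (Homo sapiens) for inhibition, read by Griess assay, with stated times of 1 h and 24 h; a higher number here means a weaker inhibitor, a lower number a stronger inhibitor. Compound 1 `CCCc1nn(C)c2c(NCc3ccc(F)cc3)nc(/C=C/c3cccnc3)nc12` carries a (4-fluorobenzyl)amino group on its core and a plain pyridine ring on the vinyl arm; in this assay compound 1 gives 940000 nM. Compound 2 `CCCc1nn(C)c2c(NC3CC3)nc(/C=C/c3ccc[n+]([O-])c3)nc12` instead carries a cyclopropylamino group and an N-oxide on the pyridine ring; in this assay compound 2 gives 580000 nM. These two numbers fall within the usual scatter of each other, so nothing can be said about which of the two is the stronger inhibitor.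

Compound 3 `CCCc1nn(C)c2c(NCc3ccc(F)cc3)nc(/C=C/c3ccc[n+]([O-])c3)nc12` has not yet been measured. It differs from compound 2 in one place: 4-fluorobenzyl in place of cyclopropyl on a nitrogen on an aromatic ring. For the measured compounds named here, no pair of measured compounds that differ only in this way is available, so there is no measured step to lean on. Since compound 1 and compound 2 already sit within the scatter of each other, no step beyond the scatter is expected here in either direction. The estimated value for compound 3 in this assay is 700000 nM, with a range from 250000 nM to 2000000 nM, which means an expected step of a 1.2-fold higher number from compound 2 to compound 3 (0.08 log units; within the scatter).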

Compound 3, half-maximal inhibitory concentration: < 40000 nM
Compound 3: a limit, no number; the forecaster's own chance of this, stated with the estimate: 15%; middle value at least 17-fold (1.24 log units) away from the limit.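

In this assay compound 3 gives a limit of the assay rather than a number: the limit of < 40000 nM in this assay, at which 1 of the 3 values shown sits.

Even so, the steps can be read as minimum sizes, and they show that the group on this nitrogen matters: putting 4-fluorobenzyl in place of cyclopropyl on a nitrogen on an aromatic ring, with the N-oxide kept, gives an at least 14-fold lower number from compound 2 to compound 3 (1.16 log units; beyond the scatter). The N-oxide on the pyridine ring matters as well: with the 4-fluorobenzyl group kept, exchanging the plain pyridine for the N-oxide gives an at least 23-fold lower number from compound 1 to compound 3 (1.37 log units; beyond the scatter). The earlier pair differ in two places at once, so neither change could be seen by itself until compound 3, the only compound shown that holds both groups, supplied a partner differing from each in one place.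

Going by these compounds, the true value of compound 3 stays unknown, and so does the full size of both steps. The compounds shown also leave open whether the fluorine contributes, which a plain benzyl group would test, and whether a larger ring such as cyclohexyl on the same nitrogen would serve as well as 4-fluorobenzyl.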